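A few compounds are considered here, and "the series" means these few. Any claim that something is new, unique, unknown or untested is made for them only; others in the source may bear on it.

Measured so far:
- compound 1 `CC(=O)OCc1ccc2oc(=O)c(C(=O)Sc3ccccc3)cc2c1` — 89.5%
- compound 2 `CCCC(=O)OCc1ccc2oc(=O)c(C(=O)Oc3cccc(Br)c3)cc2c1` — 88.6%

In a functional assay on HT-1080 cells (Homo sapiens), read by transwell migration, with a stated time of 24 h, tested at 0.1 uM (a higher number here means a weaker effect of the compound at the concentration tested, a lower number a stronger effect), compound 2 gives 88.6%, nominally the lower of the two numbers, though its gap to compound 1 at 89.5% lies within the usual scatter, so the two are not distinguishable. Compound 3 `CC(C)C(=O)OCc1ccc2oc(=O)c(C(=O)Oc3cccc(Br)c3)cc2c1` is the next point; it differs from compound 2 by isopropyl in place of propyl on a carbonyl carbon. For the measured compounds named here, no measured pair in the set isolates this change, so nothing beyond the scatter is expected in either direction. Compound 3 is expected to give 88%, ranging 78% to 97%, a step estimated as a number 0.6 percentage points lower from compound 2 to compound 3 (within the scatter).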

Compound 3, a percentage reported as activity, at one concentration (the size of the read-out at that concentration, not a potency): 54.4%
Beside the measured number, compound 3's estimate is 33.6 percentage points above it; measured number below the stated range.
By their numbers in this assay, from the lowest: compound 3; then compounds 2 and 1 (each within the scatter of the next).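

With the same atoms joined differently, isopropyl in place of propyl on a carbonyl carbon gives, in this assay, a number 34.2 percentage points lower from compound 2 to compound 3 (beyond the scatter). For the compounds shown here, this place therefore responds to how its carbons are joined, not only to how many there are, which the earlier compounds could not show. Nothing available explains the step. Still open, on these data alone, is whether tert-butyl or a longer branched chain on this carbonyl carbon extends the step, and whether isopropyl gives a similar step on the core of compound 1.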